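Chloro to methyl on a carboxy-bearing phenyl group

This account rests on a few compounds, and the source may have more. Where it says the series, first, only, none or still open, it means among the compounds named here.

Measured in an ADME assay on microsomes from liver (Rattus norvegicus) for metabolic stability, read by LC-MS, with a stated time of 1 h, at 37 degrees C, tested at 4 uM; a lower number here means that less of the compound is left, a higher number that more of the compound is left:
compound 1 `O=C1c2ccc(OCc3cccc(-c4ccccc4)c3)cc2CN1C1CCCC1`: 38%
compound 2 `O=C(O)c1cc(-c2cccc(COc3ccc4c(c3)CN(C3CCCC3)C4=O)c2)ccc1O`: 9%
compound 3 `O=C(O)c1ccc(Cl)c(-c2cccc(COc3ccc4c(c3)CN(C3CCCC3)C4=O)c2)c1`: 15%

Compound 3, at 15%, stands well under compound 1 and cannot be told apart from compound 2. Both compounds with a carboxy group lie under compound 1, with a number 29 percentage points lower from compound 1 to compound 2 (beyond the scatter) and a number 23 percentage points lower from compound 1 to compound 3 (beyond the scatter). Between those two, the data show a number 6 percentage points higher from compound 2 to compound 3 (within the scatter), even though the whole substituted phenyl group differs.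

The unmeasured compound 4 `Cc1ccc(C(=O)O)cc1-c1cccc(COc2ccc3c(c2)CN(C2CCCC2)C3=O)c1` differs from compound 3 in a single group: methyl in place of chloro on an aromatic carbon. This is methyl in place of chloro on an aromatic carbon, ortho to a large group and para to a carboxy group, so that 5-carboxy-2-chlorophenyl becomes 5-carboxy-2-methylphenyl. The carboxy group stays in place.

Among the compounds with values here, no measured step tests this exchange directly. The nearest evidence is the step of a number 6 percentage points higher from compound 2 to compound 3 (within the scatter), a larger change on the same phenyl group that stayed within the scatter. The large steps from compound 1 involve adding the carboxy group, which compound 4 retains, so they offer no reason to expect a comparable move here. In this assay, the expected outcome is a number 2 percentage points lower from compound 3 to compound 4 (within the scatter), with no shift beyond the scatter anticipated. Compound 4 is estimated at 13%, with an expected range from 5% to 25%.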

Compound 4, percent of the compound remaining: 2%
Beside the measured number, compound 4's estimate is 11 percentage points above it, and the stated range ends above it.
By their numbers in this assay, from the lowest: compounds 4, 2 and 3 (each within the scatter of the next, the first and the last beyond it); then compound 1.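

In this assay the exchange of chloro for methyl on this aromatic carbon, ortho to a large group and para to a carboxy group, gives a number 13 percentage points lower from compound 3 to compound 4 (beyond the scatter) and so moves the read-out beyond the scatter through a change of one heavy atom, something the earlier step between the two compounds with a carboxy group had not shown. The picture around it is mixed: a number 7 percentage points lower from compound 2 to compound 4 (within the scatter) stays within the scatter, while a number 36 percentage points lower from compound 1 to compound 4 (beyond the scatter) widens the distance from the compound without a carboxy group to a large step. No evidence is available on why methyl at this place leaves less of the compound than chloro.

The compounds shown leave open how a fluoro, an ethyl or a methoxy group on this same aromatic carbon would read in this assay and whether chloro and methyl would keep this order with an amide or a nitrile in place of the carboxy group. They also leave open whether a chloro and a methyl group on the phenyl of compound 1, which carries no carboxy group, would differ in the same way.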